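The source may report more compounds than this note shows. Statements on the series, on what has been measured and on what is new or still open speak of the compounds shown alone.

Measured compounds in a functional assay on RAW264.7 cells (Mus musculus) for inhibition, read by Griess assay, with stated times of 2 h and 24 h; a lower number here means a stronger inhibitor, a higher number a weaker inhibitor:
compound 1 `COc1ccc([C@@H]2CC(=O)c3c(O)cc(OCc4cn(C5CCCC5)nn4)cc3O2)cc1O`: 10500 nM
compound 2 `C#CCOc1cc(O)c2c(c1)O[C@H](c1ccc(OC)c(O)c1)CC2=O`: 20900 nM
compound 3 `COc1ccc([C@@H]2C/C(=N\O)c3c(O)cc(OCc4cn(Cc5ccccc5F)nn4)cc3O2)cc1O`: 5710 nM

All three numbers in this assay lie within the usual scatter of one another. Compound 1 is separated from neither compound 3 nor compound 2 by more than the scatter, so no ranking among the three is supported.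

Compound 4 `COc1ccc([C@@H]2CC(=O)c3c(O)cc(OCc4cn(Cc5ccccc5C#N)nn4)cc3O2)cc1O` is not yet measured. It differs from compound 1 in one place: 2-cyanobenzyl in place of cyclopentyl on an aromatic nitrogen. Within the data shown here, the only single-point step among the measured compounds, a 2.0-fold higher number from compound 1 to compound 2 (0.30 log units; within the scatter), concerns a different place, where the whole triazole is exchanged, and it stays within the scatter. Compound 3 carries a benzyl group on the same ring nitrogen as compound 4 but also differs from compound 1 at a second place, so its value, close to that of compound 1, gives only a loose hint that a benzyl group on the triazole nitrogen leaves the number near that of compound 1.

Among the measured compounds shown here, no measured step therefore points to a shift beyond the scatter for the change from cyclopentyl to 2-cyanobenzyl. The expected step is a 1.2-fold lower number from compound 1 to compound 4 (0.09 log units; within the scatter), i.e. none beyond the scatter. Compound 4 is estimated at 8500 nM in this assay, within a range of 3000 nM to 25000 nM.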

Compound 4, half-maximal inhibitory concentration: 14600 nM
Beside the measured number, compound 4's estimate is 1.7-fold (0.23 log units) below it; low and high end bracket the measured number.
By their numbers in this assay, from the lowest: compounds 3, 1, 4 and 2 (each within the scatter of the next, the first and the last beyond it).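

In this assay, among these compounds, 2-cyanobenzyl in place of cyclopentyl on the aromatic nitrogen gives a 1.4-fold higher number from compound 1 to compound 4 (0.14 log units; within the scatter), the first reading of this position with the rest of the molecule unchanged. The exchange swaps a five-membered non-aromatic ring of carbon for a six-membered aromatic ring carrying a nitrile, and this difference in the group does not separate the two numbers beyond the scatter, so the position has so far shown no sensitivity to this change. No measurement bears on why the number stays within the scatter for this exchange.

Going by these compounds, one step at this position cannot define its limits, and it remains open whether a group of another kind on the same nitrogen, such as an aminoethyl group, a carboxylic acid or a longer alkyl chain, would give a step beyond the scatter. Also open is the contribution of the nitrile itself, since a plain benzyl group on this nitrogen with the core of compound 1 unchanged does not appear among the compounds shown.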